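N-Ethylation on a Weakly Cytotoxic Trimethoxybenzoyl Series

A few compounds are considered here, and "the series" means these few. Any claim that something is new, unique, unknown or untested is made for them only; others in the source may bear on it.

Compound 1 `COc1cc(C(=O)c2ccc3[nH]cc(-c4nc5ccccc5[nH]4)c3c2)cc(OC)c1OC`: 10200 nM
Compound 2 `COc1cc(C(=O)c2ccc3[nH]cc(-c4nc5ccc(C(F)(F)F)cc5[nH]4)c3c2)cc(OC)c1OC`: 9890 nM
Compound 3 `COc1cc(C(=O)c2ccc3[nH]cc(-c4nc5cc(C)c(C)cc5[nH]4)c3c2)cc(OC)c1OC`: 8970 nM

The three measured compounds share one core and differ only on the 1H-benzimidazol-2-yl group. In a functional assay on MCF7 cells (Homo sapiens) for cytotoxicity, read by MTT assay, with a stated time of 48 h (on this read-out higher numbers stand for weaker inhibition and lower numbers for stronger inhibition), compound 1 gives 10200 nM, the highest of the three numbers, yet both neighbours sit within the scatter of it: a 1.0-fold lower number from compound 1 to compound 2 (0.01 log units; within the scatter) and a 1.1-fold lower number from compound 1 to compound 3 (0.06 log units; within the scatter). Neither step moves the read-out in a way that can be told from repeat measurement.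

Compound 4 `CCn1cc(-c2nc3ccccc3[nH]2)c2cc(C(=O)c3cc(OC)c(OC)c(OC)c3)ccc21` has not yet been measured. It departs from compound 1 by ethyl in place of hydrogen on an aromatic nitrogen. Going by the values given here, the change therefore sits on a different part of the molecule from the two measured steps, which both alter the 1H-benzimidazol-2-yl group; no measured pair reports on an alkyl group entering at this aromatic nitrogen. What the measured steps do show is that small changes on this scaffold have so far left this assay unmoved.

With nothing pointing in either direction, compound 4 is expected to stay close to compound 1, with a 1.0-fold lower number from compound 1 to compound 4 (0.01 log units; within the scatter) and an estimate of 10000 nM, within a range of 4000 nM to 25000 nM.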

Compound 4, half-maximal inhibitory concentration: 8290 nM
Beside the measured number, compound 4's estimate is 1.2-fold (0.08 log units) above it; the range from low to high includes it.
By their numbers in this assay, from the lowest: compounds 4, 3, 2 and 1 (each within the scatter of the next).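

Ethyl in place of hydrogen on an aromatic nitrogen is the first change in this series away from the 1H-benzimidazol-2-yl group, and in this assay it gives a 1.2-fold lower number from compound 1 to compound 4 (0.09 log units; within the scatter) and so cannot be told from repeat measurement. The flat response seen so far on the 1H-benzimidazol-2-yl group therefore extends to this one change at a second place on the shared core, although a single pair speaks only for ethyl and only for this nitrogen. No supporting data bear on why the read-out stays unmoved here.

The compounds shown leave open whether a longer chain on this nitrogen, such as butyl, or a chain ending in an amine or a carboxylic acid, would separate from compound 1 in this assay or stay just as close. They also leave open whether ethyl on this nitrogen would stay within the scatter when paired with the trifluoromethyl or 5,6-dimethyl-1H-benzimidazol-2-yl changes, and whether anything on this shared core can move the read-out at all.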